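The compounds below may be only part of what the source reports. "The series", "measured", "known", "first", "only" and "open" are said of these compounds alone.

Measured so far:
compound 1, `C[C@@]1(O)C[C@H]2O[C@]1(C)n1c3ccccc3c3c4c(c5c6ccccc6n2c5c31)C(=O)NC4`: 20 nM
compound 2, `C[C@]1(O)C[C@H]2O[C@]1(C)n1c3ccccc3c3c4c(c5c6ccccc6n2c5c31)C(=O)NC4`: 3 nM

In an assay on isolated protein for inhibition of high affinity nerve growth factor receptor (Homo sapiens) (on this read-out lower numbers stand for stronger inhibition and higher numbers for weaker inhibition), compound 1 gives 20 nM, and compound 2 gives 3 nM. Among the measured compounds shown here, compound 2 holds the lowest of the two numbers, its nearest neighbour being compound 1, and the step of a 6.7-fold lower number from compound 1 to compound 2 (0.82 log units; beyond the scatter) is the only measured step. This step arises because of the fact that compounds 1 and 2 differ only in the configuration as drawn; the two share every atom and bond.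

Compound 3, `C[C@]12O[C@H](C[C@@]1(O)C(N)=O)n1c3ccccc3c3c4c(c5c6ccccc6n2c5c31)CNC4=O`, is not yet measured in this assay. Relative to compound 2 the change is carbamoyl in place of methyl on a saturated ring carbon. For the measured compounds named here, the sole measured step concerns configuration alone and does not bear on the exchange of one group for another at a saturated ring carbon; no measured pair tests such an exchange. The expectation therefore rests on compound 2 alone, with no direction inferred beyond the scatter and a wide range to reflect that. Compound 3 is expected to give 5 nM in this assay, within 1 nM to 30 nM. The step this estimate implies is a 1.7-fold higher number from compound 2 to compound 3 (0.22 log units; within the scatter).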

Compound 3, half-maximal inhibitory concentration: 29 nM
Compound 3: middle estimate off by 5.8-fold (0.76 log units), on the low side, and the stated range covers the measured number.
By their numbers in this assay, from the lowest: compound 2; then compounds 1 and 3 (each within the scatter of the next).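

In this assay, among the compounds shown here, carbamoyl in place of methyl on the saturated ring carbon gives a 9.7-fold higher number from compound 2 to compound 3 (0.99 log units; beyond the scatter), the first measured exchange of one group for another, and the number moves beyond the scatter. This is the same ring carbon whose configuration changes in a 6.7-fold lower number from compound 1 to compound 2 (0.82 log units; beyond the scatter), so both its configuration and the group it carries now have a measured effect on the number, each step lying beyond the scatter. Nothing in the evidence at hand accounts for the exchange of methyl for carbamoyl, as the only available line concerns configuration.

The compounds shown do not separate the contributions of the added heavy atoms, the carbonyl and the amide hydrogens to the step, and a single exchange gives no trend across groups at this carbon. A hydroxymethyl group or a carboxylic acid here would help separate these contributions, and carbamoyl in the opposite configuration would show whether the configurational step seen with methyl carries over to this group.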